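The source may report more compounds than this note shows. Statements on the series, on what has been measured and on what is new or still open speak of the compounds shown alone.

Measured so far in a functional assay on HCT-116 cells (Homo sapiens) for inhibition, read by sulforhodamine B assay, with a stated time of 72 h; a lower number here means a stronger inhibitor, a higher number a weaker inhibitor:

compound 1, `Cc1ccc(C2=Nn3c(nnc3C(C)c3ccc(CC(C)C)cc3)SC2)cc1`, gives 4000 nM
compound 2, `COc1ccc2cc(C(C)c3nnc4n3N=C(c3ccc(C(F)(F)F)cc3)CS4)ccc2c1`, gives 10800 nM
compound 3, `CC(C)Cc1ccc(C(C)c2nnc3n2N=C(c2ccc(C(F)(F)F)cc2)CS3)cc1`, gives 6500 nM

Compound 2 stands with the highest number of the three. Its nearest neighbour is compound 3, and that gap is within the scatter, so no order can be read between the two; the gap to compound 1 is beyond the scatter. The difference between the cores of compound 2 and compound 3 is not broken down here.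

One structural change appears twice among the compounds shown. From compound 3 to compound 1 it reads (methyl in place of trifluoromethyl on an aromatic carbon), and it made a 1.6-fold lower number from compound 3 to compound 1 (0.21 log units; within the scatter).

Compound 4, `COc1ccc2cc(C(C)c3nnc4n3N=C(c3ccc(C)cc3)CS4)ccc2c1`, is not yet measured in this assay. It differs from compound 2 by methyl in place of trifluoromethyl on an aromatic carbon. For the measured compounds named here, the place of the change is described in the same words for both pairs, so this is the same change as the one from compound 3 to compound 1, now made on the core of compound 2.

Because the earlier instance gave a 1.6-fold lower number from compound 3 to compound 1 (0.21 log units; within the scatter), a step of about that size is expected for compound 4, namely a 1.6-fold lower number from compound 2 to compound 4 (0.20 log units; within the scatter). This rests on a single precedent, so the expectation is wide. Compound 4 is estimated to give 6800 nM in this assay, expected to fall between 3000 nM and 15000 nM.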

Compound 4, half-maximal inhibitory concentration: 10200 nM
Beside the measured number, compound 4's estimate is 1.5-fold (0.18 log units) below it, and the stated range covers the measured number.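

In this assay, going from 4-(trifluoromethyl)phenyl to 4-methylphenyl on the second core gave a 1.1-fold lower number from compound 2 to compound 4 (0.02 log units; within the scatter), a step too small to be told from repeat measurements. Set beside the first instance of the change, the two steps cannot be told apart: the same change on two cores in this assay, a 1.6-fold lower number (0.21 log units; within the scatter) from compound 3 to compound 1 and a 1.1-fold lower number (0.02 log units; within the scatter) from compound 2 to compound 4, 1.5-fold (0.19 log units) apart, within the scatter of two such steps

So the change carried from one core to the other without a readable difference between the two steps, and on neither core did it shift the number beyond the scatter. This does not show that the change has any real effect on either core, nor that it would behave the same way on other cores in the series, as two pairs of compounds with such small steps cannot establish a rule.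

The compounds shown carry only methyl and trifluoromethyl at this place on the aromatic ring, so it remains open whether an amine or a carboxylic acid there would give a step beyond the scatter. The other end of the molecule is also seen in only two forms, which leaves open what a longer chain on the core of compound 1 would do to the number in this assay.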